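Following a ring swap through mouse clearance

The source may report more compounds than this note shows. Statements on the series, on what has been measured and on what is new or still open speak of the compounds shown alone.

Measured in an ADME assay on the whole organism (Mus musculus, strain CD-1) for pharmacokinetics; a lower number here means slower removal, a higher number faster removal of the compound:
Compound 1 `COc1cc([C@](O)(CCN(C)C)[C@@H](c2cc3cc(Br)ccc3nc2OC)c2cccc(OC)c2F)cc(OC(C)C)n1`: 8.9 mL/min/kg
Compound 2 `COc1cc([C@](O)(CCN(C)C)[C@@H](c2cc3cc(C#N)ccc3nc2OC)c2cccc(C)c2F)cc(OC(F)F)n1`: 13 mL/min/kg

Compound 2 stands within the usual scatter of compound 1, so their two values cannot be told apart, although these compounds differ in several places. Compound 3 `COc1cc([C@](O)(CCN(C)C)[C@@H](c2cc3cc(C#N)ccc3nc2OC)c2ccnc(OC)c2OC)cc(OC(F)F)n1` changes one part of compound 2, 2,3-dimethoxypyridin-4-yl in place of 2-fluoro-3-methylphenyl on a saturated chain carbon bound to an aromatic carbon and a saturated chain carbon. Within the data shown here, no measured pair isolates this change, and no shift beyond the scatter is expected in this assay. The estimated step of a 1.1-fold higher number from compound 2 to compound 3 (0.03 log units; within the scatter) is small. For compound 3 the estimate is 14 mL/min/kg, with an expected range of 7 mL/min/kg to 28 mL/min/kg.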

Compound 3, clearance: 24 mL/min/kg
For compound 3 the middle estimate is 1.7-fold (0.23 log units) below the measured one; the measured number falls inside the stated range.
By their numbers in this assay, from the lowest: compounds 1, 2 and 3 (each within the scatter of the next, the first and the last beyond it).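

In this assay, placing 2,3-dimethoxypyridin-4-yl in place of 2-fluoro-3-methylphenyl on this saturated chain carbon gives a 1.8-fold higher number from compound 2 to compound 3 (0.27 log units; within the scatter). Compound 2 and compound 3 therefore cannot be told apart, even though the swap puts a ring nitrogen and two methoxy groups where the fluorine and methyl stood. At this position, clearance shows no clear response to that change.

Going by these compounds, the swap alters all these features at once, so their separate contributions stay open, as does the outcome with an amine on this ring. Nothing available here explains the size of the step.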